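A few compounds are considered here, and "the series" means these few. Any claim that something is new, unique, unknown or untested is made for them only; others in the source may bear on it.

Working notes on the series. In an ADME assay on microsomes from liver (Mus musculus) for metabolic stability, read by LC-MS, with a stated time of 30 min, tested at 1 uM (on this read-out higher numbers stand for a more stable compound and lower numbers for a less stable compound), compound 1 `O=C(NCc1ccc(S(=O)(=O)N2CCCCC2)cc1)c1cc2ccncc2[nH]1` gives "below limit of detection" (no number reported). Compound 2 `O=C(NCc1ccc(S(=O)(=O)N2CCCCC2)cc1)c1cnc2nccn2c1` gives 0.28%, the lower of the two numbers available, and compound 3 `O=C(NCc1ccc(S(=O)(=O)c2cc(F)cc(F)c2)cc1)c1cnc2nccn2c1` gives 71%.

Compound 4 `O=C(NCc1ccc(S(=O)(=O)N2CCCCC2)cc1)c1ccn2cncc2c1` differs from compound 2 on the carbonyl carbon: a group of 9 heavy atoms (7 carbon, 2 nitrogen; one five-membered aromatic ring with 2 hetero atoms, one six-membered aromatic ring with 1 hetero atom) in place of a group of 9 heavy atoms (6 carbon, 3 nitrogen; one five-membered aromatic ring with 2 hetero atoms, one six-membered aromatic ring with 2 hetero atoms), on a carbonyl carbon. The piperidin-1-yl on the sulfonyl sulfur stays. Within the data shown here, the only measured step is a number 70.7 percentage points higher from compound 2 to compound 3 (beyond the scatter), a large one, beyond the scatter, with 3,5-difluorophenyl in place of piperidin-1-yl on a sulfonyl sulfur. Compound 4 does not make that change, so this step offers no guide to its size. Among the measured compounds shown here, no measured step covers a change on the carbonyl carbon.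

Compound 2 at 0.28% leaves almost no room downward, so any movement is expected to be upward. The expected step is a number 1.7 percentage points higher from compound 2 to compound 4 (within the scatter), small and not beyond the scatter. For compound 4 the estimated value is 2%, with an expected range of 0% to 10%.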

Compound 4, percent of the compound remaining: 1%
Compound 4: the middle estimate sits 1 percentage points above what was measured; low and high end bracket the measured number.
By their numbers in this assay, from the lowest: compounds 2 and 4 (each within the scatter of the next); then compound 3.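

In this assay the change on the carbonyl carbon gives a number 0.7 percentage points higher from compound 2 to compound 4 (within the scatter), so with piperidin-1-yl on the sulfonyl sulfur, this exchange of one group of 9 heavy atoms for the other does not separate the two compounds. Among these compounds, the only step so far that is beyond the scatter remains a number 70.7 percentage points higher from compound 2 to compound 3 (beyond the scatter) and lies on the sulfonyl sulfur, not on the carbonyl carbon. No available measurement accounts for either step.

Still open, from the compounds shown here alone, is whether the group now on the carbonyl carbon of compound 4 would behave the same way with 3,5-difluorophenyl on the sulfonyl sulfur. Going by these compounds, it is also open how a morpholine or an unsubstituted phenyl in that sulfonyl place would compare with piperidin-1-yl and 3,5-difluorophenyl.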